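The source may report more compounds than this note shows. Statements on the series, on what has been measured and on what is new or still open speak of the compounds shown alone.

Measured in a functional assay on ASPC1 cells (Homo sapiens) for antiproliferative activity, read by MTT assay, with a stated time of 72 h; on this read-out lower numbers stand for stronger inhibition and higher numbers for weaker inhibition:
compound 1, `C=CC(=O)Nc1cc(Nc2nccc(NC(=O)c3ccccc3)n2)c(OC)cc1N1CCN(C)CC1`: > 10000 nM
compound 2, `C=CC(=O)Nc1cc(Nc2nccc(NC(=O)c3cccc4ccccc34)n2)c(OC)cc1N1CCN(C)CC1`: 6600 nM
compound 3, `C=CC(=O)Nc1cc(Nc2nccc(NC(=O)c3cccc(OC)c3)n2)c(OC)cc1N(C)CCN(C)C`: 3400 nM

The entry for compound 1 is the limit of > 10000 nM in this assay, at which 1 of the 3 values shown sits, and not a number. Compound 3 stands lowest of the two numbers; compound 2 is its nearest, within the scatter, so no order between the two can be read. Going by the values given here, the only measured step, an at least 1.5-fold lower number from compound 1 to compound 2 (0.18 log units; that floor lies within the scatter), concerns the group on the carbonyl carbon and not the change now considered. Compound 4, `C=CC(=O)Nc1cc(Nc2nccc(NC(=O)c3cccc(OC)c3)n2)c(OC)cc1N1CCN(C)CC1`, differs from compound 3 by 4-methylpiperazin-1-yl in place of (2-(dimethylamino)ethyl)(methyl)amino on an aromatic carbon. Among the compounds with values here, no measured step bears on this exchange. The step of a 1.2-fold higher number from compound 3 to compound 4 (0.07 log units; within the scatter) is therefore expected to stay within the scatter. In this assay compound 4 is estimated at 4000 nM, between 1500 nM and 11000 nM.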

Compound 4, half-maximal inhibitory concentration: > 10000 nM
Compound 4 ended at the assay's limit (the forecaster's own chance of this, stated with the estimate: 15%); at least 2.5-fold (0.39 log units) between middle value and limit.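

Going by these compounds alone, the exchange on the aromatic carbon ortho to the (vinylcarbonyl)amino group gives the first reading at this position: with the rest of the molecule unchanged, 4-methylpiperazin-1-yl in place of (2-(dimethylamino)ethyl)(methyl)amino gives an at least 2.9-fold higher number from compound 3 to compound 4 (0.46 log units; beyond the scatter) in this assay, a change beyond the scatter. The other readable step, an at least 1.5-fold higher number from compound 2 to compound 4 (0.18 log units; that floor lies within the scatter), has a floor within the scatter and sets no order, and the step involving compound 1 cannot be read. Compound 4 gives a limit and not a number, as does compound 1: the limit of > 10000 nM in this assay, at which 2 of the 4 values shown sit.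

On these data alone, how far the number for compound 4 lies past that limit stays open. So does how an open-chain amine with a longer chain, or a morpholine, would read on this carbon.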